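Nitro to Methoxy on the Sulfonyl Ring: What to Expect

The compounds below may be only part of what the source reports. "The series", "measured", "known", "first", "only" and "open" are said of these compounds alone.

Measured so far:
Compound 1 `COc1cc2c(cc1OC)C(/C(C)=N/NC(N)=S)N(S(=O)(=O)c1ccc(C)cc1)CC2` gives > 50 ug/mL in a functional assay on HepG2 cells (Homo sapiens) for cytotoxicity, read by crystal violet staining, with a stated time of 3 days (a lower number here means a stronger inhibitor, a higher number a weaker inhibitor), which is a limit of the assay and not a number.
Compound 2 `COc1cc2c(cc1OC)C(/C(C)=N/NC(N)=S)N(S(=O)(=O)c1ccc([N+](=O)[O-])cc1)CC2` gives > 50 ug/mL in this assay, again a limit and not a number.

Compound 2 thus sits where compound 1 does (the limit of > 50 ug/mL in this assay, at which 2 of the 2 values shown sit), and the step that the two limits leave unreadable from compound 1 to compound 2 is unreadable. Compound 3 `COc1ccc(S(=O)(=O)N2CCc3cc(OC)c(OC)cc3C2/C(C)=N/NC(N)=S)cc1` differs from compound 2 by methoxy in place of nitro on an aromatic carbon. No readable step bears on this change, so no step beyond the scatter is expected in this assay in either direction. Compound 3 is therefore expected to give about 50 ug/mL, within 20 ug/mL to 120 ug/mL. The expected step is a number no higher from compound 2 to compound 3 (the limit leaves the size open).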

Compound 3, half-maximal inhibitory concentration: 10.5 ug/mL
Beside the measured number, compound 3's estimate is 4.8-fold (0.68 log units) above it, and the stated range ends above it.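

Methoxy in place of nitro on this aromatic carbon gives an at least 4.7-fold lower number from compound 2 to compound 3 (0.67 log units; beyond the scatter), and methoxy in place of methyl gives an at least 4.7-fold lower number from compound 1 to compound 3 (0.67 log units; beyond the scatter), both in this assay. The group at this place can therefore change the read-out, which the earlier pair could not show, since the step between its two compounds cannot be read. These sizes are only minimum sizes, since the starting values are limits and not numbers: the limit of > 50 ug/mL in this assay, at which 2 of the 3 values shown sit.

Nitro and methyl cannot be ranked against each other. As far as these compounds go, whether an amine or a longer chain such as ethoxy at this place would give a lower number remains open.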